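The compounds below may be only part of what the source reports. "The series", "measured", "known", "first", "only" and "open" are said of these compounds alone.

Of the compounds shown here, three have been measured so far. In a functional assay on MDA-MB-231 cells (Homo sapiens) for inhibition, read by CCK-8 assay, with a stated time of 72 h, tested at 20 uM (a higher number here means more inhibition of growth at the concentration tested, a lower number less inhibition of growth), compound 1 `CCOC(=O)/C=C1/C(=O)Nc2ccccc21` gives 86.9%. Compound 2 `CC(C)(C)OC(=O)/C=C1/C(=O)Nc2ccccc21` gives 87.6% in this assay, and compound 3 `COc1ccc2c(c1)/C(=C\C(=O)OC(C)(C)C)C(=O)N2` gives 87.6%. On these numbers compound 2 stands level with compound 3 at the digits shown, and it is separated from compound 1 only by a number 0.7 percentage points higher from compound 1 to compound 2 (within the scatter); no pair among the three lies beyond the scatter.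

Compound 4 `CC(C)(C)OC(=O)/C=C1/C(=O)Nc2ccc(OC(F)(F)F)cc21` has not been measured. It differs from compound 2 by trifluoromethoxy in place of hydrogen on an aromatic carbon. For the measured compounds named here, the measured step that bears most directly on this change is the one from compound 2 to compound 3, also a replacement of hydrogen on an aromatic carbon, which gave no change at the digits printed from compound 2 to compound 3 (within the scatter). The exchange of tert-butyl for ethyl, a number 0.7 percentage points higher from compound 1 to compound 2 (within the scatter), is less closely related but likewise stayed within the scatter. With both measured steps of this size, no step beyond the scatter is expected in this assay for compound 4 in either direction. The expected step is a number 1.6 percentage points lower from compound 2 to compound 4 (within the scatter). For compound 4 the estimate is 86%, within a range from 74% to 94%.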

Compound 4, percent growth inhibition at one concentration: 86.9%
Compound 4: middle estimate off by 0.9 percentage points, on the low side; the measured number falls inside the stated range.
By their numbers in this assay, from the lowest: compounds 1, 4, 2 and 3 (each within the scatter of the next).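

In this assay, the series now tolerates two different substituents on this aromatic carbon: adding trifluoromethoxy, with its 5 heavy atoms, gives a number 0.7 percentage points lower from compound 2 to compound 4 (within the scatter), so a larger group here has not moved the read-out beyond the scatter. The change within the substituent, trifluoromethyl in place of methyl on the oxygen on the aromatic ring, is new to the series and gives a number 0.7 percentage points lower from compound 3 to compound 4 (within the scatter), so this exchange has no readable effect on growth inhibition either. No supporting data bear on why the number stays flat at this position.

From the compounds shown here alone, it remains open whether an amine or a carboxylic acid on this aromatic carbon, or a longer chain in place of tert-butyl, would shift the number beyond the scatter. With all the numbers this close, the compounds do not yet show which parts of the shared core the growth inhibition depends on.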